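Dropping a Nitro Group: Expected Effect on Membrane Activity

The source may report more compounds than this note shows. Statements on the series, on what has been measured and on what is new or still open speak of the compounds shown alone.

Of the compounds shown here, three have been measured in a functional assay on cell membranes from cells (Erythrocyte, Homo sapiens), read by spectrophotometry, with a stated time of 30 min, tested at 200 ug/mL; on this read-out higher numbers stand for a stronger effect at the one concentration tested and lower numbers for a weaker effect. Compound 1 `O=C1NCc2ccc(cc2)-c2cccc(c2)-c2ccc(cc2)CNC(=O)c2cccc(c2)OCc2ccccc2COc2cccc1c2` gives 92.4% in this assay. Compound 2 `O=C1NCc2ccc(cc2)-c2cccc(c2)-c2ccc(cc2)CNC(=O)c2cccc(c2)OCc2cc(cc([N+](=O)[O-])c2)COc2cccc1c2` gives 95.5%, and compound 3 `O=C1COc2cccc(c2)OCC(=O)NCc2ccc(cc2)-c2cccc(c2)-c2ccc(cc2)CN1` gives 96.4%. Compound 2 sits alongside both of them: its number lies within the usual scatter of compound 3 and of compound 1, so the three cannot be told apart. Compound 4 `O=C1NCc2ccc(cc2)-c2cccc(c2)-c2ccc(cc2)CNC(=O)c2cccc(c2)OCc2cccc(c2)COc2cccc1c2` has not yet been measured. It differs from compound 2 in one place: hydrogen in place of nitro on an aromatic carbon. For the measured compounds named here, no step between measured compounds shows what such a change does. Since all three measured numbers sit close together, the step of a number 1.5 percentage points lower from compound 2 to compound 4 (within the scatter) is expected to stay within the scatter. Compound 4 is therefore estimated at 94%, with a range from 86% to 99%.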

Compound 4, a percentage reported as activity, at one concentration (the size of the read-out at that concentration, not a potency): 93%
For compound 4 the middle estimate is 1 percentage points above the measured one; measured number inside the range.
By their numbers in this assay, from the lowest: compounds 1, 4, 2 and 3 (each within the scatter of the next).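

For the compounds shown here, putting hydrogen in place of nitro on this aromatic carbon gives a number 2.5 percentage points lower from compound 2 to compound 4 (within the scatter) in this assay, the first direct reading of this change. At this one concentration, then, the nitro group can leave this position with no difference that can be told from the scatter. Nothing available explains this result.

The compounds shown leave open whether an amine or a carboxylic acid on the same aromatic carbon would also stay this close to compound 4. They also leave open whether compound 2 and compound 4 would still match at lower concentrations.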